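A few compounds are considered here, and "the series" means these few. Any claim that something is new, unique, unknown or untested is made for them only; others in the source may bear on it.

Measured so far in a functional assay on Ehrlich cells (Mus musculus) for cytotoxicity, read by trypan blue exclusion, with a stated time of 2 h, tested at 50 ug/mL; on this read-out lower numbers stand for a weaker effect and higher numbers for a stronger effect at the one concentration tested:
- compound 1 `Cc1ccc(C(=O)NC2=C(C#N)C(c3ccc(Cl)cc3Cl)C3=C(CCCC3=O)N2c2ccc(S(N)(=O)=O)cc2)cc1` gives 40%
- compound 2 `N#CC1=C(/N=C/c2ccc([N+](=O)[O-])cc2[N+](=O)[O-])N(c2ccc(S(N)(=O)=O)cc2)C2=C(C(=O)CCC2)C1c1ccc(Cl)cc1Cl` gives 20%

Compound 1 stands highest of the two numbers in this assay; compound 2 is the nearest, a number lower by an amount beyond the scatter. Within the data shown here, the two measured compounds do not differ in one place only, so no single-change step is available, and what the two values show is only that compound 1 sits higher than compound 2.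

Compound 3 `CC(=O)CC(=O)NC1=C(C#N)C(c2ccc(Cl)cc2Cl)C2=C(CCCC2=O)N1c1ccc(S(N)(=O)=O)cc1` is not yet measured. Against compound 1 the change is 2-oxopropyl in place of 4-methylphenyl on a carbonyl carbon: the 4-methylphenyl with its one six-membered aromatic ring of carbon only leaves, and a 2-oxopropyl with no ring and one hydrogen-bond acceptor enters, both on the carbonyl carbon whose other neighbour is the amide-type nitrogen. Among the measured compounds shown here, with no measured step of this kind to lean on, a modest fall is expected, a number 10 percentage points lower from compound 1 to compound 3 (within the scatter), a step that is expected to reach about the edge of the usual scatter rather than clearly beyond it. Compound 3 is therefore expected to give 30% in this assay, with a range from 15% to 45%.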

Compound 3, a percentage reported as activity, at one concentration (the size of the read-out at that concentration, not a potency): 60%
Beside the measured number, compound 3's estimate is 30 percentage points below it; the measured number lies above the stated range.
By their numbers in this assay, from the lowest: compound 2; then compound 1; then compound 3.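

In this assay, among these compounds, 2-oxopropyl in place of 4-methylphenyl on the carbonyl carbon gives a number 20 percentage points higher from compound 1 to compound 3 (beyond the scatter), the only single-place step so far. The read-out therefore responds to the group at this position, and the six-membered aromatic ring of 4-methylphenyl is not needed there for an effect at the one concentration tested, since 2-oxopropyl, with no ring, also gives one. No measurement at hand bears on why the number moves.

This single step cannot separate the loss of the ring from the arrival of the hydrogen-bond acceptor, and a plain propyl chain on the same carbonyl carbon would address that. Going by these compounds, whether a longer chain such as 3-oxobutyl, or an amine in this place, would move the number further also remains open.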